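Replacing dimethoxymethyl with aminomethyl in compound 3

This account rests on a few compounds, and the source may have more. Where it says the series, first, only, none or still open, it means among the compounds named here.

Of the compounds shown here, three have numbers so far. In a functional assay on PC-3 cells (Homo sapiens), read by MTT assay, with a stated time of 48 h (a lower number here means a stronger inhibitor, a higher number a weaker inhibitor), compound 1 (`CCn1c(C(=O)NCCN)ccc1C(CC)(CC)c1ccc(OCC(=O)C(C)(C)C)c(C)c1`) gives 480 nM as its reading, compound 2 (`CCn1c(C(=O)NCCCN(C)C)ccc1C(CC)(CC)c1ccc(OCC(O)C(C)(C)C)c(C)c1`) gives 3100 nM as its reading, and compound 3 (`CCn1c(C(=O)NCC(OC)OC)ccc1C(CC)(CC)c1ccc(OCC(O)C(C)(C)C)c(C)c1`) gives 14600 nM as the highest of the three and so stands as the weakest inhibitor among them.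

Compound 4 (`CCn1c(C(=O)NCCN)ccc1C(CC)(CC)c1ccc(OCC(O)C(C)(C)C)c(C)c1`) has not been measured yet. It carries aminomethyl in place of dimethoxymethyl on a saturated chain carbon bound to an amide-type nitrogen and is otherwise the same as compound 3.

Within the data shown here, the one measured step at this place is a 4.7-fold higher number from compound 2 to compound 3 (0.67 log units; beyond the scatter) with dimethoxymethyl arriving in place of 2-(dimethylamino)ethyl. Removing dimethoxymethyl again in favour of a nitrogen-bearing group therefore points towards a lower number, though the two groups involved are not the same. Compound 1 also carries the 2-aminoethyl group and gives 480 nM as its reading, but it differs from compound 3 in more than this one place, so it is only a loose guide to how far the number could fall.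

In this assay the expected step is an 11-fold lower number from compound 3 to compound 4 (1.05 log units; beyond the scatter) and so lies beyond the scatter. The estimate for compound 4 is 1300 nM with an expected range from 400 nM to 4500 nM for now.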

Compound 4, half-maximal inhibitory concentration: 940 nM
The estimate for compound 4 lay 1.4-fold (0.14 log units) above the measured number; the measured number falls inside the stated range.
By their numbers in this assay, from the lowest: compounds 1 and 4 (each within the scatter of the next); then compound 2; then compound 3.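

In this assay, putting 2-aminoethyl in place of 2,2-dimethoxyethyl on the amide-type nitrogen gives a 16-fold lower number from compound 3 to compound 4 (1.19 log units; beyond the scatter), and amino in place of (dimethylamino)methyl, on a saturated chain carbon two bonds along the chain from that nitrogen, gives a 3.3-fold lower number from compound 2 to compound 4 (0.52 log units; beyond the scatter). With the rest of the molecule held constant, the three side chains therefore separate clearly, and the 2-aminoethyl chain of compound 4 gives the lowest number of the three, while the change at the far end of the molecule, 1-hydroxy-2,2-dimethylpropyl in place of (tert-butyl)carbonyl, gives a 2.0-fold higher number from compound 1 to compound 4 (0.29 log units; within the scatter), so with this side chain in place the alcohol and the ketone cannot be told apart. No measurement is available to explain why either change has the size it does.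

The compounds shown leave open whether the side-chain trend holds for other groups at this place, such as a 3-aminopropyl chain, a 2-(methylamino)ethyl chain or a chain ending in a carboxylic acid. They also leave open whether the alcohol and the ketone would still read alike on a side chain other than 2-aminoethyl.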